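Phenoxy on the aryl group of compound 1

A few compounds are considered here, and "the series" means these few. Any claim that something is new, unique, unknown or untested is made for them only; others in the source may bear on it.

Compound 1 `O=c1[nH]c(=O)n([C@H]2C[C@H](O)[C@@H](CO)O2)cc1-c1cn(-c2ccccc2)nn1` stands as the highest of the three numbers in an ADME assay on HeLa cells (Homo sapiens) for cytotoxicity, read by cell counting, with a stated time of 4 days (a lower number here means a stronger inhibitor, a higher number a weaker inhibitor), where compound 1 gives 56000 nM. Its nearest neighbour is compound 3 `O=c1[nH]c(=O)n([C@H]2C[C@H](O)[C@@H](CO)O2)cc1-c1cn(-c2ccc(OC(F)(F)F)cc2)nn1`, which in this assay gives 37000 nM; the step of a 1.5-fold lower number from compound 1 to compound 3 (0.18 log units; within the scatter) stays within the scatter. The furthest is compound 2 `CC(C)c1ccc(-n2cc(-c3cn([C@H]4C[C@H](O)[C@@H](CO)O4)c(=O)[nH]c3=O)nn2)cc1`, which gives 6200 nM; the step of a 9.0-fold lower number from compound 1 to compound 2 (0.96 log units; beyond the scatter) lies beyond the scatter. Compound 4 `O=c1[nH]c(=O)n([C@H]2C[C@H](O)[C@@H](CO)O2)cc1-c1cn(-c2ccc(Oc3ccccc3)cc2)nn1` differs from compound 1 by phenoxy in place of hydrogen on an aromatic carbon. The two measured steps bear on it: a hydrogen replaced by isopropyl moved the number a 9.0-fold lower number from compound 1 to compound 2 (0.96 log units; beyond the scatter), whereas trifluoromethoxy in its place moved it only a 1.5-fold lower number from compound 1 to compound 3 (0.18 log units; within the scatter), and between the two the step of a 6.0-fold higher number from compound 2 to compound 3 (0.78 log units; beyond the scatter) was modest. For the measured compounds named here, a group with one more six-membered aromatic ring has no precedent here, so the step for compound 4 is expected to lie between those two outcomes, downward, at a 3.7-fold lower number from compound 1 to compound 4 (0.57 log units; beyond the scatter). Compound 4 is therefore estimated at 15000 nM, within a range of 4000 nM to 50000 nM.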

Compound 4, half-maximal inhibitory concentration: 280 nM
Compound 4: middle estimate off by 54-fold (1.73 log units), on the high side; the measured number lies below the stated range.
By their numbers in this assay, from the lowest: compound 4; then compound 2; then compounds 3 and 1 (each within the scatter of the next).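

In this assay, for the compounds shown here, the aromatic carbon para to a large group allows a far larger drop than the earlier compounds showed: phenoxy in place of hydrogen gives a 200-fold lower number from compound 1 to compound 4 (2.30 log units; beyond the scatter), and it also outdoes isopropyl, the group with the largest earlier step, with a 22-fold lower number from compound 2 to compound 4 (1.35 log units; beyond the scatter). An oxygen on this carbon does not by itself bring the number down, since what is attached to that oxygen decides the outcome: phenyl in place of trifluoromethyl gives a 130-fold lower number from compound 3 to compound 4 (2.12 log units; beyond the scatter). No measurement at hand says why the added six-membered aromatic ring has so large an effect.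

The compounds shown leave open whether the oxygen link is needed, or whether phenyl set directly on this carbon, or benzyloxy with its longer link, would give a similar number. They also leave open how an amine or a carboxylic acid on the added ring would change the number.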